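A methyl added to the ester of compound 1

The source may report more compounds than this note shows. Statements on the series, on what has been measured and on what is new or still open speak of the compounds shown alone.

In an ADME assay on H1-HeLa cells (Homo sapiens) for cytotoxicity, read by MTT assay, with a stated time of 3 days (a higher number here means that more compound is tolerated, a lower number that less compound is tolerated), compound 1 (`CCOC(=O)c1cc2ccc(Oc3ccnc(C(=O)NC)c3)cc2s1`) reads > 100000 nM as a limit. Compound 3 (`CNC(=O)c1cc(Oc2ccc3cc(C(=O)OC)sc3c2)ccn1`) reads > 100000 nM as a limit too. Compound 2 (`CCOC(=O)c1sc2cc(Oc3ccnc(C(=O)NC)c3)ccc2c1CC`) gives a real number, 35200 nM in this assay as measured. The change to compound 4 (`CNC(=O)c1cc(Oc2ccc3cc(C(=O)OC(C)C)sc3c2)ccn1`) is methyl in place of hydrogen on a saturated chain carbon bound to an oxygen next to a carbonyl group and a saturated chain carbon and reads ethoxycarbonyl to isopropoxycarbonyl. Going by the values given here, the one measured step at this chain is a step that the two limits leave unreadable from compound 1 to compound 3 and so offers no size. Among the compounds with values here, the only readable step is an at least 2.8-fold lower number from compound 1 to compound 2 (0.45 log units; beyond the scatter) and it lies at an aromatic carbon, a different place. The expected step is an at least 1.2-fold lower number from compound 1 to compound 4 (0.09 log units; that floor lies within the scatter) and is small, toward a lower number if seen at all. For compound 4 the estimate is 80000 nM with an expected range from 30000 nM to 150000 nM and a fair chance of only a limit.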

Compound 4, half-maximal cytotoxic concentration: 45700 nM
For compound 4 the middle estimate is 1.8-fold (0.24 log units) above the measured one, and the stated range covers the measured number.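

In this assay the ester chain now gives a step with a readable size: the change from ethoxycarbonyl to isopropoxycarbonyl brings an at least 2.1-fold lower number from compound 1 to compound 4 (0.34 log units; beyond the scatter), and isopropyl in place of methyl on the same oxygen brings an at least 2.1-fold lower number from compound 3 to compound 4 (0.34 log units; beyond the scatter). The step between compound 1 and compound 3 cannot be read, so only the compounds with isopropyl on this oxygen show a change here.

From the compounds shown here alone, a longer chain on this oxygen, or a carboxylic acid in place of the ester, remains open. The full size of both steps also stays open, because compound 1 and compound 3 each stand at a limit: the limit of > 100000 nM in this assay, at which 2 of the 4 values shown sit.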